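The compounds below may be only part of what the source reports. "The series", "measured", "known", "first", "only" and "open" are said of these compounds alone.

Compound 1 `CC(C)[C@H](NC(=O)COc1cccc2ccccc12)C(=O)N[C@@H](CC(=O)O)C(=O)CSc1nc(-c2ccccc2)no1`: in a functional assay on Jurkat cells (Homo sapiens) for inhibition (on this read-out higher numbers stand for weaker inhibition and lower numbers for stronger inhibition), compound 1 gives 102000 nM.
Compound 2 `CC(C)[C@H](NC(=O)COc1cccc2ccccc12)C(=O)N[C@@H](CC(=O)O)C(=O)CSc1nnnn1C`: in this assay compound 2 gives > 200000 nM, which is a limit of the assay and not a number.
Compound 3 `Cc1cc(OCC(=O)[C@H](CC(=O)O)NC(=O)[C@@H](NC(=O)COc2cccc3ccccc23)C(C)C)nc(C)n1`: in this assay compound 3 gives > 200000 nM, again a limit of the assay.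

Compound 3 therefore stands at the upper edge of the measured range, with no number of its own; two of the three values shown sit at this limit (the limit of > 200000 nM in this assay, at which 2 of the 3 values shown sit). Compound 4 `CC(C)[C@H](NC(=O)COc1cccc2ccccc12)C(=O)N[C@@H](CC(=O)O)C(=O)COc1[nH]cnc2nncc1-2` differs from compound 3 by a group of 9 heavy atoms (5 carbon, 4 nitrogen; one five-membered aromatic ring with 2 hetero atoms, one six-membered aromatic ring with 2 hetero atoms) in place of a group of 8 heavy atoms (6 carbon, 2 nitrogen; one six-membered aromatic ring with 2 hetero atoms), on an oxygen on a saturated carbon. For the measured compounds named here, no measured step exchanges one group on this oxygen for another. The steps that touch the same saturated chain carbon, an at least 1.9-fold higher number from compound 1 to compound 3 (0.29 log units; that floor lies within the scatter), a step that the two limits leave unreadable from compound 2 to compound 3 and an at least 1.9-fold higher number from compound 1 to compound 2 (0.29 log units; that floor lies within the scatter), all stay in a region of very weak inhibition. Compound 4 is thus expected to remain weak, with an at least 1.3-fold lower number from compound 3 to compound 4 (0.12 log units; that floor lies within the scatter) meaning no change beyond the scatter. Compound 4 is estimated at 150000 nM, between 40000 nM and 400000 nM.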

Compound 4, half-maximal inhibitory concentration: 161000 nM
Beside the measured number, compound 4's estimate is 1.1-fold (0.03 log units) below it, within the range that was stated.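

Compound 2 and compound 3 stand at a limit of the assay, not at a number: the limit of > 200000 nM in this assay, at which 2 of the 4 values shown sit. Compound 4 gives a number with a group on this oxygen in this assay, and the steps are an at least 1.2-fold lower number from compound 3 to compound 4 (0.09 log units; that floor lies within the scatter) and an at least 1.2-fold lower number from compound 2 to compound 4 (0.09 log units; that floor lies within the scatter). The remaining step, a 1.6-fold higher number from compound 1 to compound 4 (0.20 log units; within the scatter), shows that the oxygen-linked group of compound 4 and the sulfur-linked group of compound 1 do not differ beyond the scatter.

The compounds shown leave open whether any group on this saturated chain carbon gives inhibition stronger than this very weak level. As far as these compounds go, an amine or a simple phenoxy group there remains untested among them.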